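The source may hold more compounds than are shown below. What is called first, only, known or untested is meant among the compounds shown, and "the series" means these compounds.

In a functional assay on HL-60 cells (Homo sapiens) for antiproliferative activity, read by sulforhodamine B assay, with a stated time of 72 h (on this read-out lower numbers stand for stronger inhibition and higher numbers for weaker inhibition), compound 1 `Cc1cccc(NC(=S)N/N=C/c2ccc3ccccc3n2)c1` is reported as > 100000 nM, which is a limit of the assay and not a number. Within the data shown here, compound 2 `Cc1ccccc1NC(=S)N/N=C/c1ccc2ccccc2n1` gives 73200 nM, the only actual number so far, so it cannot yet be ranked against a spread of values. Among the measured compounds shown here, the one measured step is an at least 1.3-fold lower number from compound 1 to compound 2 (0.13 log units; that floor lies within the scatter). Its size is only a floor, set by the limit of > 100000 nM in this assay, at which 1 of the 2 values shown sits.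

The next compound, compound 3 `S=C(N/N=C/c1ccc2ccccc2n1)Nc1ccccc1`, takes the methyl away altogether: hydrogen in place of methyl on an aromatic carbon. In words, this is hydrogen in place of methyl on an aromatic carbon, or 2-methylphenyl to phenyl. For the measured compounds named here, the measured step bears on this only indirectly, since it shifts the methyl rather than removing it, and no measured step shows the loss of the group. With so small a change and a floor that stays within the scatter, no shift beyond the scatter is foreseen in this assay, and no direction can be favoured. The expected step is a 1.0-fold lower number from compound 2 to compound 3 (0.02 log units; within the scatter). For compound 3 the estimated value is 70000 nM, with an expected range of 25000 nM to 130000 nM.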

Compound 3, half-maximal inhibitory concentration: 9130 nM
Estimate against measurement, compound 3: 7.7-fold (0.88 log units) above; measured number outside the range, below it.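

In this assay, among these compounds, hydrogen in place of methyl on an aromatic carbon gives an 8.0-fold lower number from compound 2 to compound 3 (0.90 log units; beyond the scatter), the first step that lies beyond the scatter, so the methyl on this ring is not a neutral passenger in the comparison. The same exchange starting from the 3-methylphenyl group gives an at least 10-fold lower number from compound 1 to compound 3 (1.03 log units; beyond the scatter), which places compound 3, with its plain phenyl, at a lower number than either methylphenyl compound, wherever the methyl sits in these two cases. Compound 1 stands at a limit and not at a number, so the size of this second step is only a floor: the limit of > 100000 nM in this assay, at which 1 of the 3 values shown sits.

The compounds shown carry only hydrogen or methyl on this ring, so it stays open whether the loss of activity belongs to methyl in particular or would also follow from a chlorine, a methoxy group or an amine on the same carbon. The order of the two methylphenyl compounds also remains unsettled, since the step between them is a floor within the scatter, and the shared core stays the same throughout.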